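From compound 2 to compound 4: losing the amino link

The source may hold more compounds than are shown below. What is called first, only, known or untested is meant among the compounds shown, and "the series" means these compounds.

Of the compounds shown here, three have been read so far. In an ADME assay on microsomes from liver (Homo sapiens) for metabolic stability (on this read-out higher numbers stand for a longer-lived compound and lower numbers for a shorter-lived compound), compound 1 `CCC(CC)(c1nnc[nH]1)c1ccc(-c2ccc3cc(F)cc(F)c3c2)[nH]c1=O` gives 1.76 h and compound 3 `CC(C)[C@H](C[C@H]1CCNC1=O)c1ccc(-c2ccc3cccc(F)c3c2)[nH]c1=O` gives 0.257 h. Compound 2 `CC(C)C(Nc1nnc[nH]1)c1ccc(-c2ccc3cccc(F)c3c2)[nH]c1=O` reads > 3 h, which is a limit of the assay and not a number. Compound 2 thus stands at the limit of > 3 h in this assay, at which 1 of the 3 values shown sits.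

The next compound is compound 4 `CC(C)C(c1nnc[nH]1)c1ccc(-c2ccc3cccc(F)c3c2)[nH]c1=O`. It carries 4H-1,2,4-triazol-3-yl in place of (4H-1,2,4-triazol-3-yl)amino on a saturated chain carbon bound to an aromatic carbon and a saturated chain carbon.

Among the measured compounds shown here, no two measured compounds differ in one place only, so the size of this change in this assay has no direct measure. The nearest guide is compound 1, which also carries 4H-1,2,4-triazol-3-yl and gives 1.76 h, though it differs from compound 4 elsewhere as well. Compound 3 carries neither group and offers little guidance here. On that basis a modest downward move in this assay is expected, not a collapse to the level of compound 3. The expected change is an at least 1.5-fold lower number from compound 2 to compound 4 (0.17 log units; that floor lies within the scatter). Compound 4 is estimated at 2 h, with an expected range of 0.8 h to 4 h.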

Compound 4, half-life: 0.905 h
The estimate for compound 4 lay 2.2-fold (0.34 log units) above the measured number; low and high end bracket the measured number.
By their numbers in this assay, from the lowest: compound 3; then compounds 4 and 1 (each within the scatter of the next). At a limit, above all of these: compound 2.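

Among the compounds shown here, the first one-place comparison in this assay at this saturated chain carbon bound to an aromatic carbon and a saturated chain carbon shows an at least 3.3-fold lower number from compound 2 to compound 4 (0.52 log units; beyond the scatter). With 4H-1,2,4-triazol-3-yl in place of (4H-1,2,4-triazol-3-yl)amino, the read-out therefore moves beyond the scatter, and in this pair the amino link goes with the longer-lived compound. The size of the step is only a floor, since compound 2 stands at a limit and not at a number: the limit of > 3 h in this assay, at which 1 of the 4 values shown sits.

As far as these compounds go, the full size of the step cannot be read, and it remains open whether a methylene link, an ether oxygen or a methylamino link in place of the amino link would keep the number up at the level of compound 2. Also open, from the compounds shown here alone, is whether the same exchange gives a step of like size on the diethyl-substituted carbon of compound 1, since one pair sets no pattern beyond compound 2 and compound 4.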